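Swapping Acetamido for Cyclohexylmethyl on the Side Chain

This account rests on a few compounds, and the source may have more. Where it says the series, first, only, none or still open, it means among the compounds named here.

Of the compounds shown here, three sharing one core have been measured so far. In an ADME assay on HepG2 2.2.15 cells (Homo sapiens) for cytotoxicity (a higher number here means that more compound is tolerated, a lower number that less compound is tolerated), compound 1 `CC(C)C(=O)OCCc1c(-c2ccccc2Cl)c2cc(Cl)ccc2[nH]c1=O` gives 62000 nM, and compound 2 `CCCC(=O)OCCc1c(-c2ccccc2Cl)c2cc(Cl)ccc2[nH]c1=O` gives 52000 nM. These two lie close together, a 1.2-fold lower number from compound 1 to compound 2 (0.08 log units; within the scatter). Compound 3 `CC(=O)NCC(=O)OCCc1c(-c2ccccc2Cl)c2cc(Cl)ccc2[nH]c1=O` gives 110000 nM. Its number cannot be told apart from that of its isopropyl counterpart, a 1.8-fold higher number from compound 1 to compound 3 (0.25 log units; within the scatter), but it stands clear of its propyl counterpart, a 2.1-fold higher number from compound 2 to compound 3 (0.33 log units; beyond the scatter).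

Compound 4 `O=C(CCC1CCCCC1)OCCc1c(-c2ccccc2Cl)c2cc(Cl)ccc2[nH]c1=O` differs from compound 3 by cyclohexylmethyl in place of acetamido on a saturated chain carbon bound to a carbonyl carbon. The nearest measured guide is the step to compound 3 from compound 2, a 2.1-fold higher number from compound 2 to compound 3 (0.33 log units; beyond the scatter), read here in reverse, as compound 4 also gives up acetamido for a group of carbon only. That step is modest, and it is the only one of the three that exceeds the scatter. Among the compounds with values here, no measured compound carries a ring at this place, so the guide is loose. A modest move to a lower number is therefore expected in this assay, estimated as a 2.8-fold lower number from compound 3 to compound 4 (0.44 log units; beyond the scatter). Compound 4 is estimated at 40000 nM, with an expected range from 15000 nM to 90000 nM.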

Compound 4, half-maximal cytotoxic concentration: 160000 nM
Estimate against measurement, compound 4: 4.0-fold (0.60 log units) below, and the stated range ends below it.
By their numbers in this assay, from the lowest: compounds 2, 1, 3 and 4 (each within the scatter of the next, the first and the last beyond it).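

In this assay, cyclohexylmethyl in place of acetamido on a saturated chain carbon bound to a carbonyl carbon leaves the two numbers indistinguishable, a 1.5-fold higher number from compound 3 to compound 4 (0.16 log units; within the scatter), so at this place a side chain of carbon only, with one six-membered ring and no hydrogen-bond donor or acceptor, cannot be told apart from the acetamido side chain. A side chain of carbon only therefore does not go with a lower number here, as compound 4 stands clear of both smaller carbon-only compounds, a 3.1-fold higher number from compound 2 to compound 4 (0.49 log units; beyond the scatter) and a 2.6-fold higher number from compound 1 to compound 4 (0.41 log units; beyond the scatter), and the change from the propyl group of compound 2 gives the larger of these two steps. The evidence at hand offers no explanation for why compound 4 and compound 3 fall together in this way.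

The compounds shown leave open whether the cyclohexyl ring itself or the added chain length carries the step from compound 2, since the two enter together in compound 4. They also leave open how a phenyl ring, an amine or a carboxylic acid at the end of this side chain would read in this assay.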